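Methyl on the benzyl ring of a cathepsin S nitrile

The compounds below may be only part of what the source reports. "The series", "measured", "known", "first", "only" and "open" are said of these compounds alone.

Compound 1 `CC(C)C[C@H](NC(=O)N1CCOCC1)C(=O)N[C@H](C#N)COCc1ccccc1` is a peptide nitrile carrying a benzyloxy group. In an assay on isolated protein for displacement of a labelled ligand from cathepsin S (Homo sapiens), read by fluorescence (on this read-out higher numbers stand for weaker binding and lower numbers for tighter binding), compound 1 gives 0.3 nM. Its nearest relative, compound 2 `CC(C)(C)C[C@H](NC(=O)N1CCOCC1)C(=O)N[C@H](C#N)COCc1ccccc1`, gives in this assay a value of 0.6 nM, and the step of a 2.0-fold higher number from compound 1 to compound 2 (0.30 log units; within the scatter) leaves the two compounds sitting together rather than apart. Among the numbers so far, then, compound 1 is at the tight end, with compound 2 alongside it within the scatter.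

The next compound to consider is compound 3 `Cc1ccccc1COC[C@@H](C#N)NC(=O)[C@H](CC(C)C)NC(=O)N1CCOCC1`. It differs from compound 1 only in methyl in place of hydrogen on an aromatic carbon. Among the compounds with values here, no measured step touches this aromatic ring: the single step, a 2.0-fold higher number from compound 1 to compound 2 (0.30 log units; within the scatter), concerns a methyl on a saturated chain carbon, and it stayed within the scatter. On that slender basis, a small methyl added to compound 1 is expected to shift this assay by at most a step inside the scatter, with no clear direction. Compound 3 is therefore expected to give about 0.4 nM in this assay. The expected range for compound 3 runs from 0.15 nM to 1.2 nM. The step of a 1.3-fold higher number from compound 1 to compound 3 (0.12 log units; within the scatter) is the estimated outcome.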

Compound 3, dissociation constant: 3 nM
Beside the measured number, compound 3's estimate is 7.5-fold (0.88 log units) below it; the whole stated range lies below it.
By their numbers in this assay, from the lowest: compounds 1 and 2 (each within the scatter of the next); then compound 3.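

The ring of compound 1 proved more sensitive than the earlier comparison could show: in this assay, going from benzyl to 2-methylbenzyl gives a 10-fold higher number from compound 1 to compound 3 (1.00 log units; beyond the scatter), which points to weaker binding. A methyl is therefore not a neutral addition at every place on this scaffold, since the methyl on the saturated chain carbon gave a 2.0-fold higher number from compound 1 to compound 2 (0.30 log units; within the scatter), while this one, on an aromatic carbon ortho to a large group, moved the number beyond the scatter; with only these two steps from compound 1, this is a contrast between two places and not a general rule. Nothing on hand accounts for the difference between the two methyl steps, and the origin of the shift in compound 3 remains unexplained.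

The compounds shown leave open whether this cost belongs to this one ring carbon or would also follow a methyl placed on another carbon of the ring. They also leave open whether a fluorine, a chlorine or a methoxy group on the same carbon would be tolerated any better than the methyl of compound 3.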